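The source may report more compounds than this note shows. Statements on the series, on what has been measured and on what is new or still open speak of the compounds shown alone.

Compound 1 `O=S(=O)(Nc1ccc2oc(-c3ccccc3)nc2c1)c1ccc(Cl)c(Cl)c1`: > 100000 nM
Compound 2 `O=S(=O)(Nc1ccc(-c2nc3ccccc3o2)cc1)c1ccccc1C(F)(F)F`: 74000 nM
Compound 3 `COc1cccc(S(=O)(=O)Nc2ccc3oc(-c4ccccc4)nc3c2)c1`: > 100000 nM

Of the compounds shown here, three have been measured in an assay on cells for inhibition of HSP60/HSP10 (Homo sapiens), with a stated time of 60 min; on this read-out lower numbers stand for stronger inhibition and higher numbers for weaker inhibition. Among the compounds with values here, compound 2 is the only one that yields a number, and in this assay compound 2 gives 74000 nM. For compound 1 the assay reports only a limit, > 100000 nM. For compound 3 it likewise reports only a limit, > 100000 nM. Within the data shown here, the single step between measured compounds that differ in one place, a step that the two limits leave unreadable from compound 1 to compound 3, cannot be read, since both of its ends sit at the limit of > 100000 nM in this assay, at which 2 of the 3 values shown sit.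

Compound 4 `COc1ccccc1S(=O)(=O)Nc1ccc(-c2nc3ccccc3o2)cc1` differs from compound 2 by methoxy in place of trifluoromethyl on an aromatic carbon. Among the measured compounds shown here, no measured step bears on this change; the only exchange of a group on the sulfonyl sulfur among the measured compounds is the unreadable one. The expectation for compound 4 in this assay is therefore no step beyond the usual scatter, and the estimated step is a 1.1-fold higher number from compound 2 to compound 4 (0.03 log units; within the scatter). Compound 4 is estimated at 80000 nM, within a range from 25000 nM to 250000 nM.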

Compound 4, half-maximal inhibitory concentration: > 100000 nM
Compound 4: only a limit was reported; the forecaster's own chance of this, stated with the estimate: 45%; at least 1.2-fold (0.09 log units) between middle value and limit.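

In this assay, within the data shown here, the exchange of trifluoromethyl for methoxy on an aromatic carbon, ortho to a large group, gives the first step that can be read at all: an at least 1.3-fold higher number from compound 2 to compound 4 (0.13 log units; that floor lies within the scatter). Going by these compounds, compound 4 gives > 100000 nM, which is a limit and not a number; the step therefore has a floor only, and its true size is unknown. Methoxy at this place yields no measurable number, and the read-out stays crowded at its ceiling: the limit of > 100000 nM in this assay, at which 3 of the 4 values shown sit.

On these data alone, how far compound 4 really lies from compound 2 remains open. Also open, as far as these compounds go, is whether another group on this aromatic carbon, such as an amine, a carboxylic acid or a single fluorine, would give a lower number than trifluoromethyl does.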